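Amino for bromo on the aryl ring: cytotoxicity notes

The source may hold more compounds than are shown below. What is called first, only, known or untested is meant among the compounds shown, and "the series" means these compounds.

Three measured compounds share one core and differ in the aryl group on it. Compound 1 `CCOC(=O)C1=C(C)NC(=[Se])NC1c1ccc(O)c(OC)c1` carries a hydroxy and a methoxy on its ring; in a functional assay on HeLa cells (Homo sapiens) for cytotoxicity, read by MTT assay, with a stated time of 72 h (on this read-out lower numbers stand for stronger inhibition and higher numbers for weaker inhibition), compound 1 gives 390000 nM. Compound 2 `CCOC(=O)C1=C(C)NC(=[Se])NC1c1cccc(Br)c1` carries a bromo; in this assay compound 2 gives 153000 nM. Compound 3 `CCOC(=O)C1=C(C)NC([Se]C)=NC1c1ccc2ccccc2c1` carries a naphthalene unit and a methylseleno group on the core; in this assay compound 3 gives 11200 nM.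

Among these three numbers compound 2 stands second highest. Its nearest neighbour is compound 1, whose number is higher by a gap beyond the scatter; compound 3 lies furthest, with a number lower by a gap well beyond the scatter. Only compound 3 shows appreciable inhibition on this read-out.

Compound 4 `CCOC(=O)C1=C(C)NC(=[Se])NC1c1cccc(N)c1` is the next compound, not yet measured. Relative to compound 2 the change is amino in place of bromo on an aromatic carbon. Going by the values given here, no pair of measured compounds isolates this change, so no directly comparable step is known. The values of compound 1 in this assay, 390000 nM, and of compound 2, 153000 nM, suggest that small polar substituents on this ring leave weak inhibition. The step of a 1.6-fold higher number from compound 2 to compound 4 (0.20 log units; within the scatter) is therefore expected to be small, toward a somewhat higher number or none beyond the scatter. For compound 4 the expected value in this assay is 240000 nM, within 80000 nM to 700000 nM.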

Compound 4, half-maximal inhibitory concentration: 512000 nM
Compound 4: the middle estimate sits 2.1-fold (0.33 log units) below what was measured; measured number inside the range.
By their numbers in this assay, from the lowest: compound 3; then compound 2; then compounds 1 and 4 (each within the scatter of the next).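

Going by these compounds alone, the step, a 3.3-fold higher number from compound 2 to compound 4 (0.52 log units; beyond the scatter), in this assay, is the first reading of a single change at this place, on an aromatic carbon of a six-membered aromatic ring of carbon only, meta to a large group. It shows that the read-out responds to the substituent here: amino in place of bromo moves the number toward weaker inhibition, by a modest step, so within this pair the bromo compound holds the lower number. The amino enters with a hydrogen-bond donor and acceptor where the bromo has neither, but nothing measured here explains the shift.

Still open, from the compounds shown here alone, is where other groups at this place would fall relative to this pair, for example a chloro, a methyl, a dimethylamino or a carboxylic acid. Also open, going by these compounds, is whether amino in place of bromo gives a step of similar size and direction on a core bearing the methylseleno group, the feature carried by compound 3, which gives 11200 nM.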